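From Methylsulfonyl to Chloro on a Five-Membered Ring

The compounds below may be only part of what the source reports. "The series", "measured", "known", "first", "only" and "open" are said of these compounds alone.

Two compounds with a common ketone-linked chain have been examined in an assay on HEK-293T cells for inhibition of diacylglycerol lipase-alpha (Homo sapiens), read by colorimetric assay; on this read-out higher numbers stand for weaker inhibition and lower numbers for stronger inhibition. Compound 1 `O=C(CCCCCCc1ccccc1)c1nnn[nH]1` carries a tetrazole on the carbonyl; in this assay compound 1 gives only a limit of > 10000 nM; > 10000 nM (2 entries), reported in two entries. Compound 2 `CS(=O)(=O)c1coc(C(=O)CCCCCCc2ccccc2)n1` bears instead a five-membered ring with a methylsulfonyl group, and in this assay compound 2 gives 389 nM. Among the results shown, that is the only value that is an actual number; the other entry is a limit, so compound 2 stands alone as the one measured point with a figure. Compound 3 `O=C(CCCCCCc1ccccc1)c1nc(Cl)co1` is the next compound to be measured. It differs from compound 2 in one place: chloro in place of methylsulfonyl on an aromatic carbon. Going by the values given here, no step between two measured compounds that differ in a single place is available, so the size of this change cannot be read from a precedent. The expected change is a modest weakening, a 2.1-fold higher number from compound 2 to compound 3 (0.31 log units; beyond the scatter), though a result within the scatter would not surprise. Compound 3 is therefore estimated at 800 nM, within a range from 150 nM to 5000 nM.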

Compound 3, half-maximal inhibitory concentration: 2400 nM
Compound 3: the middle estimate sits 3.0-fold (0.48 log units) below what was measured; low and high end bracket the measured number.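

In this assay, going by these compounds alone, replacing methylsulfonyl with chloro on the aromatic carbon next to the ring nitrogen gives a 6.2-fold higher number from compound 2 to compound 3 (0.79 log units; beyond the scatter), the first step that can be read between two measured compounds differing in one place. It shows that this position on the five-membered aromatic ring is not indifferent to the group it carries: the number moves beyond the usual scatter when the group of 4 heavy atoms, with its 2 hydrogen-bond acceptors, gives way to a single chlorine, and methylsulfonyl is the one of the two with the lower number. Within the data shown here, no measurement at hand bears on what lies behind this difference, so the single step stands as an observation only.

The compounds shown leave open how a nitrile, a methyl group, an amine or a plain hydrogen on the same aromatic carbon would compare with methylsulfonyl and chloro. They also leave open whether the step keeps its size on a shorter chain, as compound 2 and compound 3 share one ketone-linked chain.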